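A few compounds are considered here, and "the series" means these few. Any claim that something is new, unique, unknown or untested is made for them only; others in the source may bear on it.

Measured so far in a toxicity assay on THP-1 cells (Homo sapiens) for inhibition; on this read-out lower numbers stand for higher toxicity in this test and higher numbers for lower toxicity in this test:
compound 1 `COc1ccc(-c2cnc(NC(=O)C3CCOCC3)n2C)cc1`, > 100000 nM, a limit of the assay rather than a number
compound 2 `Cn1c(-c2ccc([N+](=O)[O-])cc2)cnc1NC(=O)c1ccc(F)cc1`, > 50000 nM, likewise a limit of the assay

Compound 1 therefore stands at the limit of > 100000 nM in this assay, at which 1 of the 2 values shown sits, and no measured number places it anywhere. Compound 2 sits at the limit of > 50000 nM in this assay, at which 1 of the 2 values shown sits. Within the data shown here, neither value shown is a number, so no step between measured compounds exists for this series.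

Compound 3 `COc1ccc(-c2cnc(NC(=O)c3ccncc3)n2C)cc1` differs from compound 1 by pyridin-4-yl in place of oxan-4-yl on a carbonyl carbon. Among the measured compounds shown here, no measured pair covers this change, so in this assay the expected step is none beyond the usual scatter, with compound 3 likely again at the limit. Compound 3 is expected at 100000 nM, range 30000 nM to 300000 nM, an expected step of a number no higher from compound 1 to compound 3 (the limit leaves the size open).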

Compound 3, half-maximal cytotoxic concentration: > 100000 nM
Compound 3 ended at the assay's limit (the forecaster's own chance of this, stated with the estimate: 70%); the middle value sits exactly at the limit.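

In this assay, compound 1 and compound 3 both rest at an assay limit, so no step can be read between them. The compounds shown leave open whether any change on this carbonyl carbon gives a measurable number.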